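The source may report more compounds than this note shows. Statements on the series, on what has been measured and on what is new or still open speak of the compounds shown alone.

Working notes on a small series of cytotoxicity data.

Compound 1 `O=C(Cn1c(=O)oc2cc(Cl)ccc21)Nc1cc(C(F)(F)F)ccc1Cl` is measured in an ADME assay on RAW264.7 cells (Mus musculus) for cytotoxicity, read by MTT assay, with a stated time of 72 h, tested at 50 uM (on this read-out higher numbers stand for a stronger effect at the one concentration tested and lower numbers for a weaker effect), where compound 1 gives 1.61%. Compound 2 `O=C(Cn1c(=O)oc2cc(Cl)ccc21)Nc1nc2ccc([N+](=O)[O-])cc2s1` gives 12.5% in this assay, and compound 3 `O=C(Cn1c(=O)oc2cc([N+](=O)[O-])ccc21)Nc1nc2ccc([N+](=O)[O-])cc2s1` gives 14.8%. Compound 1 and compound 2 share the same amide-linked core but differ on the other side of the amide; that difference between the two cores is not broken down here. Compound 3 differs from compound 2 by nitro in place of chloro on an aromatic carbon, and this step gives a number 2.3 percentage points higher from compound 2 to compound 3 (within the scatter).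

Compound 4 `O=C(Cn1c(=O)oc2cc([N+](=O)[O-])ccc21)Nc1cc(C(F)(F)F)ccc1Cl` is not yet measured in this assay. Among the measured compounds shown here, it differs from compound 1 by nitro in place of chloro on an aromatic carbon, which is the same change as the one from compound 2 to compound 3, at the same place on the same ring. Because a number 2.3 percentage points higher from compound 2 to compound 3 (within the scatter) lies within the scatter, the corresponding step in this assay is expected to be small, a number 2.4 percentage points higher from compound 1 to compound 4 (within the scatter), with compound 1 as the starting point. For the measured compounds named here, on that basis compound 4 is estimated to give 4% in this assay, within a range of -4% to 13%; this estimate rests on only one earlier instance of the change.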

Compound 4, a percentage reported as inhibition, at one concentration (the size of the read-out at that concentration, not a potency): 12.8%
The estimate for compound 4 lay 8.8 percentage points below the measured number; low and high end bracket the measured number.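

In this assay, nitro in place of chloro on an aromatic carbon gives a number 11.2 percentage points higher from compound 1 to compound 4 (beyond the scatter), and set beside the earlier instance of the change, the two steps cannot be told apart: the same change on two cores in this assay, a number 2.3 percentage points higher (within the scatter) from compound 2 to compound 3 and a number 11.2 percentage points higher (beyond the scatter) from compound 1 to compound 4, 8.9 percentage points apart, within the scatter of two such steps.

Among the compounds shown here, as far as these two cores go, the change therefore carries over with no step size distinct from the other, even though only one of the two steps lies beyond the scatter on its own. This does not fix a size for the change or show that it would hold on any further core, since it rests on two pairs read at a single concentration.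

The compounds shown leave open how an amine, a carboxylic acid or a nitrile would compare with chloro and nitro at this place on the ring. Also open, as far as these compounds go, is whether the step persists when the other side of the amide carries something else, such as a longer chain.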